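The source may hold more compounds than are shown below. What is called first, only, known or untested is meant among the compounds shown, and "the series" means these compounds.

Compound 1 `COC(=O)/C(=C\c1ccc(OC(=O)c2cc(OC)cc(OC)c2)cc1)Sc1ccnc2cc(Cl)ccc12` gives in a functional assay on Jurkat E6.1 cells (Homo sapiens) for cytotoxicity, read by MTT assay, with a stated time of 24 h (a lower number here means a stronger inhibitor, a higher number a weaker inhibitor), a result of 28900 nM.
Compound 2 `COC(=O)/C(=C\c1ccc(OC(=O)c2ccc(OC)c(OC)c2)cc1)Sc1ccnc2cc(Cl)ccc12` gives in this assay a result of 8290 nM.
Compound 3 `COC(=O)/C(=C\c1ccc(OC(=O)c2c(OC)cccc2OC)cc1)Sc1ccnc2cc(Cl)ccc12` gives in this assay a result of 37500 nM.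

Compound 3 has the highest of the three numbers in this assay. Its nearest neighbour is compound 1, from which it differs by a 1.3-fold higher number from compound 1 to compound 3 (0.11 log units; within the scatter); its furthest is compound 2, and the step of a 4.5-fold higher number from compound 2 to compound 3 (0.66 log units; beyond the scatter) is the largest among the three. Compound 4 `COC(=O)/C(=C\c1ccc(OC(=O)c2ccc(OC)c(OC)c2OC)cc1)Sc1ccnc2cc(Cl)ccc12` differs from compound 3 in one place: 2,3,4-trimethoxyphenyl in place of 2,6-dimethoxyphenyl on a carbonyl carbon. Within the data shown here, no measured step makes exactly this change. The step of a 4.5-fold higher number from compound 2 to compound 3 (0.66 log units; beyond the scatter) shows that moving two methoxy groups from the 2,6-dimethoxyphenyl arrangement to the 3,4-dimethoxyphenyl arrangement gave a modest improvement, while a 3.5-fold lower number from compound 1 to compound 2 (0.54 log units; beyond the scatter) points the same way. Compound 4 carries the 2,3,4-trimethoxyphenyl group in place of the 2,6-dimethoxyphenyl group, so a modest step to a lower number in this assay is expected, estimated as a 2.5-fold lower number from compound 3 to compound 4 (0.40 log units; beyond the scatter). For compound 4 the estimate in this assay is 15000 nM, in a range from 5000 nM to 45000 nM.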

Compound 4, half-maximal inhibitory concentration: 2410 nM
Beside the measured number, compound 4's estimate is 6.2-fold (0.79 log units) above it, and the stated range ends above it.
By their numbers in this assay, from the lowest: compound 4; then compound 2; then compounds 1 and 3 (each within the scatter of the next).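

In this assay, among these compounds, methoxy in place of hydrogen on an aromatic carbon gave a 3.4-fold lower number from compound 2 to compound 4 (0.54 log units; beyond the scatter), which shows that this aryl group on the carbonyl carbon accepts a further methoxy group and gains from it, whereas the earlier compounds only rearranged two methoxy groups. The 2,3,4-trimethoxyphenyl group also gave a 16-fold lower number from compound 3 to compound 4 (1.19 log units; beyond the scatter) and a 12-fold lower number from compound 1 to compound 4 (1.08 log units; beyond the scatter), both larger than the widest gap among the dimethoxyphenyl compounds, a 4.5-fold higher number from compound 2 to compound 3 (0.66 log units; beyond the scatter), and makes compound 4 the strongest of the four. Nothing given here explains why this group has such an effect.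

The compounds shown leave open whether the gain is specific to methoxy, or whether a hydroxyl group, a fluorine atom or an amine on the same aromatic carbon would give a similar step. They also leave open whether a longer alkoxy chain there would be accepted.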